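Piperidin-1-yl in Place of Methyl on the Shared Core

This account rests on a few compounds, and the source may have more. Where it says the series, first, only, none or still open, it means among the compounds named here.

Three compounds carrying the same (2-hydroxyethoxy)methyl group have been tested in a functional assay on L1210 cells (Mus musculus) for inhibition; on this read-out higher numbers stand for weaker inhibition and lower numbers for stronger inhibition. Compound 1 `O=c1[nH]c(=O)n(COCCO)cc1[N+](=O)[O-]` gives only a limit in this assay, > 1000 ug/mL. Compound 2 `Nc1nc(=O)ccn1COCCO` also gives a limit rather than a number, > 500 ug/mL. Compound 3 `Cc1nc2c(O)nc(N)nc2n1COCCO` likewise reaches only a limit in this assay, > 500 ug/mL. Compound 3 therefore stands at the limit of > 500 ug/mL in this assay, at which 2 of the 3 values shown sit, where compound 2 also sits, while compound 1 sits at the limit of > 1000 ug/mL in this assay, at which 1 of the 3 values shown sits; none of the three has produced a measured number, so no ordering among them can be read from the data.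

Compound 4 `Nc1nc(O)c2nc(N3CCCCC3)n(COCCO)c2n1` has not yet been measured. It differs from compound 3 in one place: piperidin-1-yl in place of methyl on an aromatic carbon. The methyl that leaves brings one carbon; the piperidin-1-yl that enters brings one six-membered non-aromatic ring with one hetero atom and one hydrogen-bond acceptor, on an aromatic carbon of the five-membered aromatic ring of the fused system.

Within the data shown here, no step between measured compounds exists here to set a size for this change. Compound 4 is expected to remain at a limit, with a step of a number no higher from compound 3 to compound 4 (the limit leaves the size open) that is no larger than the scatter. Compound 4 is estimated at 500 ug/mL, between 100 ug/mL and 1000 ug/mL.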

Compound 4, concentration for 50% inhibition: > 500 ug/mL
Compound 4 ended at the assay's limit; the forecaster's own chance of this, stated with the estimate: 70%; the middle value sits exactly at the limit.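

Compound 3 and compound 4 both end at a limit in this assay, so no step between them can be read: the limit of > 500 ug/mL in this assay, at which 3 of the 4 values shown sit.

The compounds shown leave open whether piperidin-1-yl in place of methyl on the shared core changes inhibition at all, and in which direction.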